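The source may hold more compounds than are shown below. What is called first, only, known or untested is meant among the compounds shown, and "the series" means these compounds.

Within the data shown here, compound 2, with the structure `CNC(=O)c1cc(C(=O)NC2CC2)cn(Cc2ccc3nc[nH]c3c2)c1=O`, is one of two compounds measured in a physicochemical assay for solubility, read by HPLC, in simulated intestinal fluid, with a stated time of 16 h, tested at 125 ug/mL (a lower number here means a less soluble compound, a higher number a more soluble compound), and there compound 2 gives 225 ug/mL. Its only companion, compound 1, with the structure `CNC(=O)c1cc(C(=O)NC2CCC2)cn(Cc2ccncc2)c1=O`, gives in this assay a value of 121 ug/mL. Compound 2 has the higher of the two numbers, but the gap to compound 1 lies within the scatter of repeated runs, so no order between them can be claimed.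

Compound 3, with the structure `CNC(=O)c1cc(C(=O)NC2CC2)cn(Cc2cccc3[nH]ccc23)c1=O`, has not yet been measured in this assay. It differs from compound 2 in one place: 1H-indol-4-yl in place of 1H-benzimidazol-6-yl on a saturated chain carbon bound to an aromatic nitrogen. Among the measured compounds shown here, no step between two measured compounds exists to guide the reading of this change.

The expectation for compound 3 is therefore a modest decrease, roughly at the edge of the scatter, expressed as a 2.0-fold lower number from compound 2 to compound 3 (0.31 log units; beyond the scatter). Compound 3 is estimated to reach 110 ug/mL in this assay, with a range from 45 ug/mL to 230 ug/mL.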

Compound 3, solubility: 17 ug/mL
For compound 3 the middle estimate is 6.5-fold (0.81 log units) above the measured one; the whole stated range lies above it.
By their numbers in this assay, from the lowest: compound 3; then compounds 1 and 2 (each within the scatter of the next).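

Among these compounds, at the saturated chain carbon bound to an aromatic nitrogen, the two groups are not interchangeable in this assay: 1H-indol-4-yl in place of 1H-benzimidazol-6-yl gives a 13-fold lower number from compound 2 to compound 3 (1.12 log units; beyond the scatter), the first readable step at this position. The step is large even though the two groups match in heavy atoms and hydrogen-bond donors, while the change swaps a ring nitrogen for carbon and, as the names show, moves the point of attachment. No measurement given here accounts for the size of this step.

The compounds shown leave open whether the ring nitrogen or the point of attachment carries the step, a question that 1H-indol-6-yl or 1H-benzimidazol-4-yl at this place would separate. Also open, on these data alone, is how an amine or a carboxylic acid on the 1H-indol-4-yl group would read in this assay.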